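Removing the trifluoromethyl group from compound 3

A few compounds are considered here, and "the series" means these few. Any claim that something is new, unique, unknown or untested is made for them only; others in the source may bear on it.

Measured in a functional assay on MCF7 cells (Homo sapiens) for inhibition, read by sulforhodamine B assay; a higher number here means a weaker inhibitor, a lower number a stronger inhibitor:
Compound 1 `O=C1C=C(NCc2ccccc2)C(=O)c2c1nc1n2[C@H]2OC[C@@H](O)[C@H]2OC1`: > 8000 nM (a limit)
Compound 2 `CCc1ccc(NC2=CC(=O)c3nc4n(c3C2=O)[C@H]2OC[C@@H](O)[C@H]2OC4)cc1`: 960 nM
Compound 3 `O=C1C=C(Nc2ccc(C(F)(F)F)cc2)C(=O)c2c1nc1n2[C@H]2OC[C@@H](O)[C@H]2OC1`: > 4000 nM (a limit)

Compound 3 has no exact number, and its result of > 4000 nM is only a limit. Compound 4 `O=C1C=C(Nc2ccccc2)C(=O)c2c1nc1n2[C@H]2OC[C@@H](O)[C@H]2OC1` differs from it in one place: hydrogen in place of trifluoromethyl on an aromatic carbon, para to a large group (hydrogen in place of trifluoromethyl on an aromatic carbon).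

For the measured compounds named here, two measured steps bear on this change. The closest is an at least 4.1-fold higher number from compound 2 to compound 3 (0.61 log units; beyond the scatter), where trifluoromethyl replaces ethyl at the same place, so the group there can shift the result. The other is an at least 8.3-fold lower number from compound 1 to compound 2 (0.92 log units; beyond the scatter), where 4-ethylphenyl replaces benzyl. Neither step tests hydrogen directly, so the forecast is loose. Compound 4 lacks both the ethyl of compound 2 and the trifluoromethyl of compound 3, so a result between those two compounds in this assay seems the most likely outcome. The estimated change is an at least 1.6-fold lower number from compound 3 to compound 4 (0.20 log units; that floor lies within the scatter). For compound 4 the expected value is 2500 nM, with an estimated range of 900 nM to 7000 nM.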

Compound 4, half-maximal inhibitory concentration: > 4000 nM
Compound 4: only a limit was reported; the forecaster's own chance of this, stated with the estimate: 30%; middle value at least 1.6-fold (0.20 log units) away from the limit.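

In this assay, compound 4, with hydrogen at this place on the ring, gives > 4000 nM, which is a limit. Taking the ethyl away altogether gives an at least 4.1-fold higher number from compound 2 to compound 4 (0.61 log units; beyond the scatter), so the plain phenyl, like the 4-(trifluoromethyl)phenyl, falls short of the 4-ethylphenyl, and compound 2 is the only one of the four with an exact number. The steps joining compound 4 to compound 3 and to compound 1 cannot be read, because all three results are limits: the limit of > 4000 nM in this assay, at which 2 of the 4 values shown sit.

Going by these compounds, how hydrogen and trifluoromethyl rank against each other therefore stays open, as does how far either lies past the limit. Also open, on these data alone, is whether ethyl is special here, or whether a methyl, a propyl or a methoxy at the same place would give an exact number too.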